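This account rests on a few compounds, and the source may have more. Where it says the series, first, only, none or still open, it means among the compounds named here.

Measured so far in an assay on HEK293 cells for antagonist activity at P2X purinoceptor 7 (Homo sapiens), read by fluorescence, with a stated time of 2 h; on this read-out lower numbers stand for stronger inhibition and higher numbers for weaker inhibition:
compound 1 `COc1ccc(C(=O)N2CCC(n3cncc3-c3ccc(OS(=O)(=O)c4cccc5cnccc45)cc3)CC2)cc1` — 77 nM
compound 2 `CN(C)c1ccc(C(=O)N2CCC(n3cncc3-c3ccc(OS(=O)(=O)c4cccc(C(=O)NC5CC5)c4)cc3)CC2)cc1` — 0.49 nM

Compound 2 holds the lower of the two numbers; compound 1 sits well above it, and the gap between them lies beyond the scatter. Going by the values given here, the two differ in more than one place, so no single step is read from them.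

Compound 3 `COc1ccc(C(=O)N2CCC(n3cncc3-c3ccc(OS(=O)(=O)c4cccc(C(=O)NC5CC5)c4)cc3)CC2)cc1` keeps the core of compound 2 and changes one group: methoxy in place of dimethylamino on an aromatic carbon. Among the compounds with values here, no measured pair isolates this change. A small loss is expected for compound 3, a 2.4-fold higher number from compound 2 to compound 3 (0.39 log units; beyond the scatter), within or near the scatter. Compound 3 is estimated at 1.2 nM, range 0.35 nM to 5 nM.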

Compound 3, half-maximal inhibitory concentration: 244 nM
Compound 3: middle estimate off by 200-fold (2.31 log units), on the low side, outside the stated range (above it).
By their numbers in this assay, from the lowest: compound 2; then compound 1; then compound 3.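

In this assay, the position para to a large group proves highly sensitive: 4-(dimethylamino)phenyl changing to 4-methoxyphenyl gives a large step (a 500-fold higher number from compound 2 to compound 3 (2.70 log units; beyond the scatter)). With 4-methoxyphenyl held, 3-(cyclopropylcarbamoyl)phenyl in place of isoquinolin-5-yl on the sulfonyl sulfur gives only a modest step (a 3.2-fold higher number from compound 1 to compound 3 (0.50 log units; beyond the scatter)). The data at hand offer no explanation for the size of either step.

As far as these compounds go, how an unsubstituted amine, a methylamino group or a pyrrolidine would stand on this aromatic carbon remains open. Also open, from the compounds shown here alone, is whether the dimethylamino to methoxy step repeats with isoquinolin-5-yl on the sulfonyl sulfur.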